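Notes on compound 2: fluoro in place of methyl

This account rests on a few compounds, and the source may have more. Where it says the series, first, only, none or still open, it means among the compounds named here.

Compound 1 `O=C1COc2ccc(-c3cccc(NS(=O)(=O)c4ccc(F)cc4)c3)cc2N1C1CC1` gives > 40000 nM as a limit
Compound 2 `Cc1ccc(N2C(=O)COc3ccc(-c4cccc(NS(=O)(=O)c5ccc(F)cc5)c4)cc32)cc1` gives 36200 nM as a number
Compound 3 `O=C1COc2ccc(-c3cccc(NS(=O)(=O)c4ccc(F)cc4)c3)cc2N1c1ccc(F)cc1` is not yet measured

All values come from a functional assay on A-375 cells (Homo sapiens) for antiproliferative activity, read by MTT assay, with a stated time of 72 h (a higher number here means a weaker inhibitor, a lower number a stronger inhibitor), in this series. Compound 1 stands at > 40000 nM as a limit of the assay and not as a number. Among the compounds with values here, compound 2 holds the only numerical value so far, 36200 nM in this set, so it has no numerical rank among the compounds. Compound 3 differs from compound 2 by fluoro in place of methyl on an aromatic carbon as fluoro in place of methyl on an aromatic carbon, para to a large group.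

One measured step exists, an at least 1.1-fold lower number from compound 1 to compound 2 (0.04 log units; that floor lies within the scatter) for a different change, and it replaces cyclopropyl with 4-methylphenyl. Within the data shown here, no measured step tests the methyl or fluoro group, and that step from compound 1 to compound 2 gives no basis for a direction. The estimated change is a 1.0-fold lower number from compound 2 to compound 3 (0.01 log units; within the scatter) and no shift beyond the scatter is expected. For compound 3 the expected value is 35000 nM with an estimated range from 15000 nM to 60000 nM in this assay. A reported limit for compound 3 also remains possible.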

Compound 3, half-maximal inhibitory concentration: > 40000 nM
Compound 3: a limit, no number; the forecaster's own chance of this, stated with the estimate: 35%; middle value at least 1.1-fold (0.05 log units) away from the limit.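

In this assay, fluoro in place of methyl on an aromatic carbon, para to a large group, gives an at least 1.1-fold higher number from compound 2 to compound 3 (0.04 log units; that floor lies within the scatter), so this first test of the position shows no lower number, and the true size of the step cannot be read. Compound 3 gives > 40000 nM, which is a limit of the assay and not a number. The step from compound 1 to compound 3 cannot be read, and the series now stands mostly at the edge of the measurable range: the limit of > 40000 nM in this assay, at which 2 of the 3 values shown sit.

Compound 2 gives 36200 nM. As far as these compounds go, whether a methoxy group, an amine or a carboxylic acid in that place on the ring would give a clearly lower number than compound 2 stays open. Also open, from the compounds shown here alone, is whether the methyl group of compound 2 matters to that number at all, with a single comparison at this position and a floor that lies within the scatter.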